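The source may hold more compounds than are shown below. What is called first, only, known or untested is meant among the compounds shown, and "the series" means these compounds.

Compound 1 `O=C1OCC[C@@H]1NC(=S)SCCOc1ccccc1` and compound 2 `O=C1OCC[C@@H]1NC(=S)SCCOc1ccccc1[N+](=O)[O-]` share a core; compound 2 carries nitro in place of hydrogen on an aromatic carbon. In a functional assay on MCF7 cells (Homo sapiens) for antiproliferative activity, read by MTT assay, with a stated time of 72 h (on this read-out higher numbers stand for weaker inhibition and lower numbers for stronger inhibition), compound 1 gives > 64000 nM, which is a limit of the assay. Compound 2 gives > 64000 nM in this assay, again a limit. The step that the two limits leave unreadable from compound 1 to compound 2 cannot be sized, since the limit of > 64000 nM in this assay, at which 3 of the 3 values shown sit, marks where all three values sit. Compound 3 `O=C(COc1ccc(C(=O)/C=C/c2ccccc2)cc1)N[C@H]1CCOC1=O` has a core whose difference from the core of compound 1 is not broken down here. In this assay compound 3 gives > 64000 nM, a limit. Compound 4 `O=C(COc1ccc(C(=O)/C=C/c2cccc([N+](=O)[O-])c2)cc1)N[C@H]1CCOC1=O` carries the same kind of change, (nitro in place of hydrogen on an aromatic carbon), the place differing in that the nitro sits meta to a large group rather than ortho to one. With the step from compound 1 to compound 2 unreadable, the step of a number no higher from compound 3 to compound 4 (the limit leaves the size open) for compound 4 is expected to be flat. Compound 4 is expected at 64000 nM, estimated between 20000 nM and 200000 nM.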

Compound 4, half-maximal inhibitory concentration: > 64000 nM
Compound 4: a limit, no number; the forecaster's own chance of this, stated with the estimate: 80%; the middle value lies on the limit itself.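

No new step can be read between compound 3 and compound 4, since both values are limits: the limit of > 64000 nM in this assay, at which 4 of the 4 values shown sit.

The compounds shown leave open whether nitro in place of hydrogen on an aromatic carbon changes the read-out at all, as none of the four gives a number.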